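Half-life of compound 3 and its piperidin-1-yl change

The source may report more compounds than this note shows. Statements on the series, on what has been measured and on what is new or still open speak of the compounds shown alone.

Values in an ADME assay on microsomes from liver (Mus musculus) for metabolic stability, read by HPLC, with a stated time of 4 h (a higher number here means that the compound lasts longer, a lower number that the compound disappears faster), so far
- compound 1 (`CN(C)c1ccc2cc(-c3nc(-c4ccccc4)cs3)c(N)nc2c1`) gives 0.31 h
- compound 2 (`CN(C)c1ccc2cc(-c3nc4ccccc4s3)c(N)nc2c1`) gives 0.2 h
- compound 3 (`CNc1ccc2cc(-c3cc(Cl)cc(Cl)c3)c(N)nc2c1`) gives > 4 h as a limit

Compound 3 gives only a limit, (the limit of > 4 h in this assay, at which 1 of the 3 values shown sits), and no number is known for it. Compound 1 (0.31 h) and compound 2 (0.2 h) show that short half-lives occur in this series. Compound 4 (`Nc1nc2cc(N3CCCCC3)ccc2cc1-c1cc(Cl)cc(Cl)c1`) is compound 3 with piperidin-1-yl in place of methylamino on an aromatic carbon. Within the data shown here, no measured pair isolates this change, so a moderate fall in this assay is expected, with a result at the limit still possible. The expected step runs an at least 2.6-fold lower number from compound 3 to compound 4 (0.42 log units; beyond the scatter), a fall beyond the scatter. Compound 4 is estimated at 1.5 h, within an expected range of 0.4 h to 4 h.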

Compound 4, half-life: 0.1 h
Compound 4: middle estimate off by 15-fold (1.18 log units), on the high side; the whole stated range lies above it.
By their numbers in this assay, from the lowest: compounds 4, 2 and 1 (each within the scatter of the next, the first and the last beyond it). At a limit, above all of these: compound 3.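

In this assay, piperidin-1-yl in place of methylamino on this aromatic carbon gives an at least 40-fold lower number from compound 3 to compound 4 (1.60 log units; beyond the scatter), with the rest of the structure the same. This shows that a change at this one position alone can shorten the half-life sharply. On these data alone, the true size of the step stays unknown, as compound 3 gives a limit and not a number: the limit of > 4 h in this assay, at which 1 of the 4 values shown sits.

The change both removes a hydrogen-bond donor and brings in a ring, and this single pair does not separate the two. Open, as far as these compounds go, is how a plain amino group or a morpholin-4-yl ring on the same carbon would stand.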